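Oxygen for Sulfur in a Small Five-Membered Ring

A few compounds are considered here, and "the series" means these few. Any claim that something is new, unique, unknown or untested is made for them only; others in the source may bear on it.

Measured in a functional assay on MDA-MB-435S cells (Homo sapiens) for cytotoxicity, read by MTT assay, with a stated time of 72 h; on this read-out higher numbers stand for weaker inhibition and lower numbers for stronger inhibition:
Compound 1 `Cc1cc(C)n2nc(SCc3nnc(SCc4coc5ccccc5c4=O)n3N)nc2n1`: compound 1 gives 3000 nM.
Compound 2 `Cc1nnc(SCc2cc(=O)c3ccccc3o2)s1`: compound 2 gives > 25000 nM.

Compound 1 is the only one of the two with a measured number in this assay. Compound 2 stands at a limit of this assay, recorded as > 25000 nM, which is a limit and not a measured number. This is the situation described by the limit of > 25000 nM in this assay, at which 1 of the 2 values shown sits. Among the compounds with values here, no step between two measured compounds exists here, so nothing about the size of a change in this assay can be read from the data directly.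

Compound 3 `Cc1nnc(SCc2cc(=O)c3ccccc3o2)o1` is the next compound to be tested. It differs from compound 2 in one place: 5-methyl-1,3,4-oxadiazol-2-yl in place of 5-methyl-1,3,4-thiadiazol-2-yl on a sulfur. The rest of the molecule is the same as in compound 2. Within the data shown here, with compound 2 sitting at a limit and no measured step to lean on, the expectation for compound 3 is a step that the limit leaves unreadable from compound 2 to compound 3 that is none beyond the usual scatter, and it is quite possible that this assay will again report only a limit. Compound 3 is accordingly estimated at 30000 nM in this assay, with a range from 10000 nM to 100000 nM.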

Compound 3, half-maximal inhibitory concentration: > 25000 nM
Compound 3 gave a limit, no number (the forecaster's own chance of this, stated with the estimate: 80%); the middle value is on the limit's open side.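

Compound 2 and compound 3 each give only a limit in this assay, not a measured number, so no step can be read for 5-methyl-1,3,4-oxadiazol-2-yl in place of 5-methyl-1,3,4-thiadiazol-2-yl: the limit of > 25000 nM in this assay, at which 2 of the 3 values shown sit.

The compounds shown leave open whether this exchange changes the result in this assay at all.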